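Fluoro to trifluoromethoxy in a series at its limit

The source may report more compounds than this note shows. Statements on the series, on what has been measured and on what is new or still open speak of the compounds shown alone.

Measured in a functional assay on RAW264.7 cells (Mus musculus) for inhibition, read by fluorescence, with stated times of 1 h, 24 h and 30 min; a higher number here means a weaker inhibitor, a lower number a stronger inhibitor:
- compound 1 `O=C(/C=C/c1ccccc1F)c1ccccc1`: > 10000 nM
- compound 2 `O=C(/C=C/c1ccccc1F)c1cccc(O)c1`: > 10000 nM
- compound 3 `O=C(/C=C/c1cccc(F)c1)c1ccccc1O`: > 10000 nM

Each of these entries is a limit and not a number. Among the measured compounds shown here, the series so far stands at the limit of > 10000 nM in this assay, at which 3 of the 3 values shown sit.

Compound 2 gives > 10000 nM in this assay, which is a limit, so it offers no exact starting point.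

Compound 4 `O=C(/C=C/c1ccccc1OC(F)(F)F)c1cccc(O)c1` is not yet measured. It keeps the hydroxy of compound 2 and carries trifluoromethoxy in place of fluoro on an aromatic carbon, ortho to a large group: trifluoromethoxy in place of fluoro on an aromatic carbon.

For the measured compounds named here, the only measured step that bears on this is a step that the two limits leave unreadable from compound 1 to compound 2. That step concerns the hydroxy, not the fluoro, and it has no readable size. Going by the values given here, no measured step exchanges the fluoro for another group, so the series gives no size or direction to carry over.

The working expectation in this assay is therefore no step beyond the scatter, with a report at the limit the likeliest outcome. The expected step is a step that the limit leaves unreadable from compound 2 to compound 4. For compound 4 the estimate is 12000 nM, with an expected range from 4000 nM to 40000 nM.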

Compound 4, half-maximal inhibitory concentration: 1610 nM
Compound 4: the middle estimate sits 7.5-fold (0.87 log units) above what was measured; the whole stated range lies above it.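

In this assay, trifluoromethoxy in place of fluoro on an aromatic carbon, ortho to a large group, gives an at least 6.2-fold lower number from compound 2 to compound 4 (0.79 log units; beyond the scatter). Compound 2 stands at > 10000 nM, which is a limit. The one earlier step, hydroxy in place of hydrogen on an aromatic carbon, cannot be read, so this exchange is the first change in the series with a readable size, and it shows that this position can take compound 4 off the limit where the other compounds remain: the limit of > 10000 nM in this assay, at which 3 of the 4 values shown sit.

Going by these compounds, whether the drop needs trifluoromethoxy itself stays open, and methoxy, chloro or trifluoromethyl at this place would test that. Also open, on these data alone, is whether the hydroxy is needed for the value of compound 4, 1610 nM, a question that a trifluoromethoxy compound without that hydroxy would answer.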